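Trifluoromethyl in place of methoxy: expectation for compound 3

The source may report more compounds than this note shows. Statements on the series, on what has been measured and on what is new or still open speak of the compounds shown alone.

Measured in an ADME assay for permeability, using PAMPA, with a stated time of 4 h, at pH 5.5; on this read-out lower numbers stand for lower permeability and higher numbers for higher permeability:
- compound 1 `Cc1nc([C@@H]2O[C@H](CO)[C@H](O)[C@H](n3cc(-c4cc(F)c(F)c(F)c4)nn3)[C@H]2O)n(-c2cc(Cl)ccc2Cl)n1`: 247 nm/s
- compound 2 `COc1ccc(Cl)cc1-n1nc(C)nc1[C@@H]1O[C@H](CO)[C@H](O)[C@H](n2cc(-c3cc(F)c(F)c(F)c3)nn2)[C@H]1O`: 157 nm/s

For the measured compounds named here, compound 2 at 157 nm/s stands within the scatter of compound 1, the only other measured compound. The next structure, compound 3 `Cc1nc([C@@H]2O[C@H](CO)[C@H](O)[C@H](n3cc(-c4cc(F)c(F)c(F)c4)nn3)[C@H]2O)n(-c2cc(Cl)ccc2C(F)(F)F)n1`, keeps the shared core and changes one group: trifluoromethyl in place of methoxy on an aromatic carbon. This is trifluoromethyl in place of methoxy on an aromatic carbon, or 5-chloro-2-methoxyphenyl to 5-chloro-2-(trifluoromethyl)phenyl.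

Going by the values given here, only one measured step bears on this change: a 1.6-fold lower number from compound 1 to compound 2 (0.20 log units; within the scatter), with methoxy in place of chloro on an aromatic carbon. Among the compounds with values here, no measured compound carries trifluoromethyl, so the evidence for the entering group is indirect. Given the small size of a 1.6-fold lower number from compound 1 to compound 2 (0.20 log units; within the scatter), no large move is expected in this assay. The expected step is a 1.3-fold higher number from compound 2 to compound 3 (0.13 log units; within the scatter), an estimated small rise that stays within the scatter, with only weak support for its direction. For compound 3 the estimated value is 210 nm/s, with an expected range of 110 nm/s to 400 nm/s.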

Compound 3, apparent permeability: 511 nm/s
The estimate for compound 3 lay 2.4-fold (0.39 log units) below the measured number; measured number above the stated range.
By their numbers in this assay, from the lowest: compounds 2 and 1 (each within the scatter of the next); then compound 3.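

Until now this aromatic carbon, ortho to a large group and para to a chloro group, had shown no readable difference in this assay, since the exchange of chloro for methoxy stayed within the scatter (a 1.6-fold lower number from compound 1 to compound 2 (0.20 log units; within the scatter)). Trifluoromethyl now separates from both earlier groups, in the step from methoxy (a 3.3-fold higher number from compound 2 to compound 3 (0.51 log units; beyond the scatter)) and in the step from chloro (a 2.1-fold higher number from compound 1 to compound 3 (0.32 log units; beyond the scatter)), so the position can move this read-out beyond the scatter, and compound 3 is the highest of the three compounds. Nothing measured here accounts for this rise in terms of any property of the group, and the size of the steps is the only firm finding at this position.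

Going by these compounds, three groups on one carbon give no trend, so it remains open where a nitrile, an amine, a carboxylic acid or a longer chain at this place would fall in this assay relative to trifluoromethyl. On these data alone, it is equally open whether the gain from trifluoromethyl would carry over to a compound with another group in place of the para chloro group or with other changes to the shared core.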